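Shifting the methoxy group on the aryl substituent

The compounds below may be only part of what the source reports. "The series", "measured", "known", "first", "only" and "open" are said of these compounds alone.

The three measured compounds, all tested in an assay on isolated protein for inhibition of RAC-beta serine/threonine-protein kinase (Homo sapiens), read by mobility shift assay, tested at 30 uM; a higher number here means more inhibition at the concentration tested (going by the name of the read-out), a lower number less inhibition:
compound 1 `CC(C)(C)c1cc2nn(-c3ccccc3)c(N)c2c(=O)[nH]1` gives 3%;
compound 2 `Nc1c2c(=O)[nH]c(-c3ccccn3)cc2nn1-c1ccccc1` gives 8%;
compound 3 `COc1ccccc1-c1cc2nn(-c3ccccc3)c(N)c2c(=O)[nH]1` gives 0%.

Compound 3 carries the lowest of the three numbers, but both gaps, a number 3 percentage points lower from compound 1 to compound 3 (within the scatter) and a number 8 percentage points lower from compound 2 to compound 3 (within the scatter), lie within the scatter, so none of the three can be told apart. Compound 4 `COc1ccc(-c2cc3nn(-c4ccccc4)c(N)c3c(=O)[nH]2)cc1` keeps the same atoms joined differently: 4-methoxyphenyl in place of 2-methoxyphenyl on an aromatic carbon. Every measured step swaps a whole group at this carbon, including a number 5 percentage points higher from compound 1 to compound 2 (within the scatter), and each stays within the scatter. Nothing measured moves the methoxy group alone. In this assay compound 4 is therefore expected to show a number 3 percentage points higher from compound 3 to compound 4 (within the scatter), an estimate of 3% with a range from -5% to 12%.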

Compound 4, a percentage reported as inhibition, at one concentration (the size of the read-out at that concentration, not a potency): 0%
The estimate for compound 4 lay 3 percentage points above the measured number, and the stated range covers the measured number.
By their numbers in this assay, from the lowest: compounds 3, 4, 1 and 2 (each within the scatter of the next).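

In this assay moving the methoxy group alone, from 2-methoxyphenyl to 4-methoxyphenyl, gives no change at the digits printed from compound 3 to compound 4 (within the scatter) and so shows no readable effect of where that group sits on the ring. Swapping whole groups reads the same way, with a number 8 percentage points lower from compound 2 to compound 4 (within the scatter) and a number 3 percentage points lower from compound 1 to compound 4 (within the scatter) as well. No supporting evidence bears on this result.

Still open, from the compounds shown here alone, is whether any group at this carbon, such as a carboxylic acid or a primary amine, would lift the number beyond the scatter.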